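Anilide in place of benzylamide at the amide nitrogen

The source may report more compounds than this note shows. Statements on the series, on what has been measured and on what is new or still open speak of the compounds shown alone.

Compound 1 `CNC(=O)[C@H](c1ccc(Cl)cc1)C(C)C` reaches 66% in a functional assay on CHO cells for agonist activity at Free fatty acid receptor 2 (Homo sapiens), read by cAMP accumulation; on this read-out higher numbers stand for larger maximal responses and lower numbers for smaller maximal responses. Compound 2 `CC(C)[C@H](C(=O)NCc1ccccc1)c1ccc(Cl)cc1` is reported only at a limit of this assay, < 30%. Among the measured compounds shown here, the one measured step, a number at least 36 percentage points lower from compound 1 to compound 2 (beyond the scatter), is a large loss; compound 2 sits at the limit of < 30% in this assay, at which 1 of the 2 values shown sits. Compound 3 `CC(C)[C@H](C(=O)Nc1ccccc1)c1ccc(Cl)cc1` differs from compound 2 by phenyl in place of benzyl on an amide-type nitrogen. For the measured compounds named here, no measured step covers this change, so the direction is open. Compound 3 is expected to give a modest rise, a number at least 5 percentage points higher from compound 2 to compound 3 (that floor lies within the scatter), and an estimated efficacy of 35%, ranging from 15% to 60%.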

Compound 3, largest response reached (reported as efficacy), in percent of the reference or control that the assay uses: < 30%
Compound 3 gave a limit, no number; the forecaster's own chance of this, stated with the estimate: 45%; middle value at least 5 percentage points from the limit.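

In this assay compound 3 gives < 30%, which is a limit of the assay and not a number. The step from benzyl to phenyl on the amide-type nitrogen cannot be read, since both of its ends are limits: the limit of < 30% in this assay, at which 2 of the 3 values shown sit. Measured against methyl, phenyl gives a number at least 36 percentage points lower from compound 1 to compound 3 (beyond the scatter), so a large loss on this nitrogen comes with phenyl as well as with benzyl.

Still open, as far as these compounds go, is whether ethyl or a short chain ending in an amine on this nitrogen would keep the response seen with methyl.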